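This account rests on a few compounds, and the source may have more. Where it says the series, first, only, none or still open, it means among the compounds named here.

Compound 1 `O=c1[nH]cnc2c1c(-c1ccoc1)cn2[C@@H]1O[C@H](CO)[C@@H](O)[C@H]1O` was examined in an ADME assay on BJ cells (Homo sapiens), read by MTT assay, with a stated time of 72 h; a lower number here means a stronger inhibitor, a higher number a weaker inhibitor. In this assay compound 1 gives > 100000 nM, which is a limit of the assay and not a number. Where compound 1 stands is therefore known only through (the limit of > 100000 nM in this assay, at which 1 of the 2 values shown sits), so its true value could lie anywhere past that point. Compound 2 `CN(C)c1ncnc2c1c(-c1ccoc1)cn2[C@@H]1O[C@H](CO)[C@@H](O)[C@H]1O`, another member of the same set, is a measured neighbour; in this assay compound 2 gives 99200 nM, a weak result close to the same region.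

Compound 3 `O=c1[nH]cnc2c1c(-c1cccs1)cn2[C@@H]1O[C@H](CO)[C@@H](O)[C@H]1O` differs from compound 1 in one place: thiophen-2-yl in place of furan-3-yl on an aromatic carbon. Among the compounds with values here, no step between measured compounds is available to calibrate this change. With compound 1 sitting at the limit and compound 2 giving a similarly weak number, the change from compound 1 to compound 3 is expected to produce no step beyond the usual scatter of this assay. Compound 3 is therefore expected to give about 100000 nM, within a range from 30000 nM to 300000 nM, and the expected step is a number no higher from compound 1 to compound 3 (the limit leaves the size open).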

Compound 3, half-maximal inhibitory concentration: > 100000 nM
Compound 3 ended at the assay's limit (the forecaster's own chance of this, stated with the estimate: 65%); the middle value lies on the limit itself.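

Compound 1 and compound 3 both end at a limit of this assay, not at a number, so no step between them can be read: the limit of > 100000 nM in this assay, at which 2 of the 3 values shown sit.

The compounds shown leave open how far past that limit each true value lies, and whether thiophen-2-yl and furan-3-yl differ at all.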